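Swapping Fluorines for Chlorines on the Amide Aryl Ring

The compounds below may be only part of what the source reports. "The series", "measured", "known", "first", "only" and "open" are said of these compounds alone.

Of the compounds shown here, three sharing one core have been tested in a functional assay on SK-BR-3 cells (Homo sapiens) for antiproliferative activity, read by MTT assay, with a stated time of 72 h; a higher number here means a weaker inhibitor, a lower number a stronger inhibitor. Compound 1 `CCN1CCN(c2cc(C)c3cc(NC(=O)c4ccccc4C)ccc3n2)CC1` gives 29200 nM, compound 2 `CCN1CCN(c2cc(C)c3cc(NC(=O)c4ccc(Cl)cc4)ccc3n2)CC1` gives 3020 nM, and compound 3 `CCN1CCN(c2cc(C)c3cc(NC(=O)c4ccc(F)c(F)c4)ccc3n2)CC1` gives 1980 nM. Compound 3 has the lowest number of the three, yet its gap to compound 2 is within the scatter, so the two cannot be ranked; only a 15-fold lower number from compound 1 to compound 3 (1.17 log units; beyond the scatter) is a clear step.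

Compound 4 `CCN1CCN(c2cc(C)c3cc(NC(=O)c4ccc(Cl)c(Cl)c4)ccc3n2)CC1` differs from compound 3 by 3,4-dichlorophenyl in place of 3,4-difluorophenyl on a carbonyl carbon. The bearing comparison is a 1.5-fold lower number from compound 2 to compound 3 (0.18 log units; within the scatter), where a chlorine-bearing and a fluorine-bearing ring gave numbers within the scatter, so halogen identity has so far made little difference. For compound 4 a step of a 1.3-fold lower number from compound 3 to compound 4 (0.12 log units; within the scatter) in this assay is therefore expected, with an estimate of 1500 nM and a range from 500 nM to 5000 nM.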

Compound 4, half-maximal inhibitory concentration: 2160 nM
Compound 4: the middle estimate sits 1.4-fold (0.16 log units) below what was measured, within the range that was stated.
By their numbers in this assay, from the lowest: compounds 3, 4 and 2 (each within the scatter of the next); then compound 1.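

In this assay, exchanging both fluorines for chlorines on the ring at the carbonyl carbon gives a 1.1-fold higher number from compound 3 to compound 4 (0.04 log units; within the scatter), and chloro in place of hydrogen on that ring gives a 1.4-fold lower number from compound 2 to compound 4 (0.15 log units; within the scatter), so neither change separates these compounds. The 2-methylphenyl compound remains apart, with a 14-fold lower number from compound 1 to compound 4 (1.13 log units; beyond the scatter). Nothing measured here offers a reason for either result.

Still open, as far as these compounds go, is whether a 4-methoxyphenyl or a pyridyl group at the same carbonyl carbon would give numbers like those of compound 2, compound 3 and compound 4, or like that of compound 1.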